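A few compounds are considered here, and "the series" means these few. Any claim that something is new, unique, unknown or untested is made for them only; others in the source may bear on it.

Measured in a functional assay on A549 cells (Homo sapiens) for antiproliferative activity, read by MTT assay, with a stated time of 48 h; on this read-out higher numbers stand for weaker inhibition and lower numbers for stronger inhibition:

compound 1, `COc1ccc(C(=O)c2ccc(OC)c3c2OC(C)(C)C=C3)c(NC(=O)CN)c1`: 270 nM
compound 2, `COc1ccc(C(=O)c2ccc3c(c2)C=CC(C)(C)O3)c(NC(=O)CN)c1`: 310 nM
compound 3, `CNCC(=O)Nc1cc(OC)ccc1C(=O)c1ccc(OC)c2c1OC(C)(C)C=C2`: 620 nM

Compound 1 and compound 3 share a core; compound 2 carries a different core, and the difference between the two cores is not broken down here. Compound 1 and compound 2 give numbers within the scatter of each other in this assay, so no order between them is drawn. Compound 3 differs from compound 1 by methyl in place of hydrogen on an amine nitrogen, and this gave a 2.3-fold higher number from compound 1 to compound 3 (0.36 log units; beyond the scatter).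

Compound 4, `CNCC(=O)Nc1cc(OC)ccc1C(=O)c1ccc2c(c1)C=CC(C)(C)O2`, is not yet measured. It differs from compound 2 by methyl in place of hydrogen on an amine nitrogen, the same change as from compound 1 to compound 3: the place lines read the same word for word, an amine nitrogen whose other neighbours are a saturated chain carbon. The change has been made only once among the measured compounds, so the expectation rests on a single pair.

On the core of compound 2 the change is expected to read about as it did on the core of compound 1, because a 2.3-fold higher number from compound 1 to compound 3 (0.36 log units; beyond the scatter) was modest but beyond the scatter; the estimated step is a 2.1-fold higher number from compound 2 to compound 4 (0.32 log units; beyond the scatter). For compound 4 in this assay the expected number is 650 nM, with a range of 350 nM to 1300 nM to allow for the step resting on one pair.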

Compound 4, half-maximal inhibitory concentration: 800 nM
For compound 4 the middle estimate is 1.2-fold (0.09 log units) below the measured one, and the stated range covers the measured number.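

In this assay, methyl in place of hydrogen on an amine nitrogen gives a 2.6-fold higher number from compound 2 to compound 4 (0.41 log units; beyond the scatter), so the direction seen on the core of compound 1 also appears on the core of compound 2. The two steps do not differ beyond the scatter, and for these two cores the change carries over at about the same size: the same change on two cores in this assay, a 2.3-fold higher number (0.36 log units; beyond the scatter) from compound 1 to compound 3 and a 2.6-fold higher number (0.41 log units; beyond the scatter) from compound 2 to compound 4, 1.1-fold (0.05 log units) apart, within the scatter of two such steps. Among these compounds, this rests on only two pairs in a single cell assay, so it does not show that the step would hold on a further core or in another read-out, and it says nothing about the origin of the step.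

The compounds shown leave open whether a larger group on this nitrogen, such as ethyl, isopropyl or a second methyl giving a dimethylamino group, extends the same trend or departs from it. They also leave open how the series reads when the aminomethyl group gives way to a longer chain such as aminoethyl, or when the amine is replaced by a hydroxyl group or a carboxylic acid.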